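Cytotoxicity notes: trifluoromethyl in place of methoxy

A few compounds are considered here, and "the series" means these few. Any claim that something is new, unique, unknown or untested is made for them only; others in the source may bear on it.

Compound 1 `O=C(NCCO)c1cc2c(Nc3ccc(OC(F)(F)F)cc3)ncnc2s1` and compound 2 `COc1ccc(Nc2cc(-c3ccncc3)ncn2)cc1` have both been run in an ADME assay on BaF3 cells (Mus musculus) for cytotoxicity; a lower number here means that less compound is needed, a higher number that more compound is needed for the effect. In this assay compound 1 reports only a limit, > 10000 nM. In this assay compound 2 likewise reports only a limit, > 10000 nM. Both results sit at the limit of > 10000 nM in this assay, at which 2 of the 2 values shown sit, so compound 2 stands at the top of the measured range and cannot be ranked against compound 1 by number.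

Compound 3 `FC(F)(F)c1ccc(Nc2cc(-c3ccncc3)ncn2)cc1` is the next member of the series: trifluoromethyl in place of methoxy on an aromatic carbon, on an aromatic carbon of a six-membered aromatic ring of carbon only, para to a large group. Among the compounds with values here, no measured pair shows this change, so its size is open. With both measured compounds at the limit, no movement beyond the scatter in either direction is foreseen. The step expected in this assay is a step that the limit leaves unreadable from compound 2 to compound 3, within the scatter. Compound 3 is expected to give 15000 nM in this assay, within 5000 nM to 50000 nM, most likely reported again as a limit.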

Compound 3, half-maximal effective concentration: > 10000 nM
Compound 3: no number, only a limit; the forecaster's own chance of this, stated with the estimate: 80%; the middle value does not contradict the limit.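

In this assay, within the data shown here, compound 2 and compound 3 both report only a limit, so no step between them can be read: the limit of > 10000 nM in this assay, at which 3 of the 3 values shown sit. The compounds shown leave open where any of them would give a measured number, and whether trifluoromethyl in place of methoxy changes it at all.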